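The source may hold more compounds than are shown below. What is called first, only, known or untested is meant among the compounds shown, and "the series" means these compounds.

In a functional assay on PANC-1 cells (Homo sapiens) for inhibition, read by MTT assay, with a stated time of 24 h (on this read-out higher numbers stand for weaker inhibition and lower numbers for stronger inhibition), compound 1 (`CC1(C)[C@H]2CC[C@]1(C)N(Cc1cn(-c3ccc(C#N)cc3)nn1)C(=O)C2`) gives 250 nM and compound 2 (`CC1(C)[C@H]2CC[C@]1(C)N(Cc1cn(-c3ccc(F)cc3)nn1)C(=O)C2`) gives 110 nM. Compound 2 therefore holds the lower of the two numbers and is the stronger inhibitor of this pair. Compound 3 (`CC1(C)[C@H]2CC[C@]1(C)N(Cc1cn(-c3ccc(Br)cc3)nn1)C(=O)C2`) keeps the shared core and alters one group: bromo in place of fluoro on an aromatic carbon.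

For the measured compounds named here, only one measured step bears on this change: a 2.3-fold lower number from compound 1 to compound 2 (0.36 log units; beyond the scatter), a modest step in which fluoro replaced cyano on that same carbon. Going by the values given here, no bromo compound has been measured yet, so this single step gives no firm direction. In this assay, a step no larger than that one is expected, quite possibly none beyond the scatter. The expected change is a 1.1-fold higher number from compound 2 to compound 3 (0.04 log units; within the scatter). The estimated value for compound 3 is 120 nM, with an expected range from 50 nM to 280 nM.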

Compound 3, half-maximal inhibitory concentration: 200 nM
Estimate against measurement, compound 3: 1.7-fold (0.22 log units) below; measured number inside the range.
By their numbers in this assay, from the lowest: compounds 2, 3 and 1 (each within the scatter of the next, the first and the last beyond it).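

In this assay, putting bromo in place of fluoro on this aromatic carbon gives a 1.8-fold higher number from compound 2 to compound 3 (0.26 log units; within the scatter), so the 4-bromophenyl compound cannot be told apart from the 4-fluorophenyl compound, and this position accepts a second halogen without a clear loss. Bromo in place of the nitrile gives a 1.3-fold lower number from compound 1 to compound 3 (0.10 log units; within the scatter), so compound 3 cannot be told apart from compound 1 either, and it sits within the scatter of two compounds whose own gap lies beyond it. Nothing available explains how these three groups compare.

On these data alone, whether chloro, methoxy, an amine or a carboxylic acid on this same carbon would fit within this narrow band remains open. Also open, as far as these compounds go, is whether plain hydrogen there would give a number clearly apart from those of these three compounds.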